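The compounds below may be only part of what the source reports. "The series", "measured", "known", "first", "only" and "open" are said of these compounds alone.

Measured in a functional assay on OVCAR-3 cells (Homo sapiens) for antiproliferative activity, read by spectrophotometry, with a stated time of 2 days; on this read-out lower numbers stand for stronger inhibition of growth and higher numbers for weaker inhibition of growth:

Compound 1 `CN(c1cccc2c1CN(c1nc(Nc3ccc(C(F)(F)F)cc3)ncc1C(F)(F)F)C2)S(C)(=O)=O`: > 30000 nM, a limit
Compound 2 `Cc1cc(Cl)ccc1Nc1ncc(C(F)(F)F)c(N2Cc3cccc(N(C)S(C)(=O)=O)c3C2)n1`: > 30000 nM, a limit

Compound 2 gives > 30000 nM, which is a limit of the assay and not a number. The picture so far is the limit of > 30000 nM in this assay, at which 2 of the 2 values shown sit.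

Compound 3 `CN(c1cccc2c1CN(c1nc(Nc3ccc(Cl)c(C(F)(F)F)c3)ncc1C(F)(F)F)C2)S(C)(=O)=O` carries 4-chloro-3-(trifluoromethyl)phenyl in place of the 4-chloro-2-methylphenyl of compound 2, on a nitrogen on an aromatic ring: 4-chloro-3-(trifluoromethyl)phenyl in place of 4-chloro-2-methylphenyl on a nitrogen on an aromatic ring.

One measured step changed the group at this same place: a step that the two limits leave unreadable from compound 1 to compound 2. It gives no size to carry over, so the data support no expected shift in either direction. In this assay no step beyond the scatter is expected, and a further limit is quite possible. The expected step is an at least 1.2-fold lower number from compound 2 to compound 3 (0.07 log units; that floor lies within the scatter). Compound 3 is estimated at 25000 nM, with an expected range from 8000 nM to 40000 nM.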

Compound 3, concentration for 50% growth inhibition: > 50000 nM
Compound 3 gave a limit, no number; the forecaster's own chance of this, stated with the estimate: 60%; at least 2.0-fold (0.30 log units) between middle value and limit.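

Going by these compounds alone, compound 1, compound 2 and compound 3 all sit at limits of the assay rather than at numbers, and no step among them can be read. The compounds shown leave open whether any of these three groups on the nitrogen gives measurable inhibition of growth.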